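Replacing the aminophenyl arm of compound 1 with a dimethylphenyl arm

The compounds below may be only part of what the source reports. "The series", "measured", "known", "first", "only" and "open" are said of these compounds alone.

Compound 1 `COc1cc(-n2cnc3ccc(-c4cccc(N)c4)cc32)cc(OC)c1OC` gives the lowest number of the three measured in a functional assay on A549 cells (Homo sapiens) for antiproliferative activity, read by MTT assay, with a stated time of 72 h (on this read-out lower numbers stand for stronger inhibition and higher numbers for weaker inhibition), at 640 nM. Its nearest neighbour is compound 3 `COc1cccc(-c2ccc3ncn(-c4cc(OC)c(OC)c(OC)c4)c3c2)c1`, which gives 3180 nM, while compound 2 `COc1cc(-n2cnc3ccc(-c4cccc(F)c4)cc32)cc(OC)c1OC` gives 5270 nM. The two steps away from compound 1 are both beyond the scatter: a 5.0-fold higher number from compound 1 to compound 3 (0.70 log units; beyond the scatter) and an 8.2-fold higher number from compound 1 to compound 2 (0.92 log units; beyond the scatter). Between compound 2 and compound 3, a 1.7-fold lower number from compound 2 to compound 3 (0.22 log units; within the scatter), so those two cannot be ordered.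

Compound 4 `COc1cc(-n2cnc3ccc(-c4cccc(C)c4C)cc32)cc(OC)c1OC` differs from compound 1 in one place: 2,3-dimethylphenyl in place of 3-aminophenyl on an aromatic carbon. The change sits on an aromatic carbon of a six-membered aromatic ring of carbon only, part of a fused or bridged system of two rings; meta to a fused ring; para to a fused ring.

Among the compounds with values here, the steps that bear on this are the two in which the amino group of compound 1 was exchanged for something else, fluoro in compound 2 and methoxy in compound 3, and each raised the number by a modest, clearly resolved amount. A 2,3-dimethylphenyl group is a third kind of replacement for the 3-aminophenyl, so a rise of similar size is expected in this assay, with the step estimated as a 5.5-fold higher number from compound 1 to compound 4 (0.74 log units; beyond the scatter). For compound 4 the expected value is 3500 nM, estimated to lie between 1200 nM and 10000 nM.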

Compound 4, half-maximal inhibitory concentration: 9250 nM
Compound 4: middle estimate off by 2.6-fold (0.42 log units), on the low side; measured number inside the range.
By their numbers in this assay, from the lowest: compound 1; then compounds 3, 2 and 4 (each within the scatter of the next, the first and the last beyond it).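

In this assay, the 2,3-dimethylphenyl arm gives the first step away from the 3-aminophenyl arm of compound 1 that is graded large (a 14-fold higher number from compound 1 to compound 4 (1.16 log units; beyond the scatter)), so at this position on the shared core, a replacement can cost more than the modest steps seen with fluoro and methoxy. The arms lacking the amino group are not all alike either, since the change from the 3-methoxyphenyl arm is resolved (a 2.9-fold higher number from compound 3 to compound 4 (0.46 log units; beyond the scatter)), whereas the change from the 3-fluorophenyl arm stays within the scatter (a 1.8-fold higher number from compound 2 to compound 4 (0.24 log units; within the scatter)) and leaves compound 2 and compound 4 unordered. Nothing measured here accounts for these differences.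

The compounds shown do not separate the loss of the amino group from the addition of two methyl groups, as an aryl arm carrying a single methyl group would be needed to do that. They also leave open whether the low number of compound 1 is specific to the primary amine or would be shared by a hydroxyl, a methylamino group or an aminomethyl group on the same arm.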